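This account rests on a few compounds, and the source may have more. Where it says the series, first, only, none or still open, it means among the compounds named here.

Measured in an assay for inhibition of 15-hydroxyprostaglandin dehydrogenase [NAD(+)] (Homo sapiens), read by fluorescence and spectrophotometry; on this read-out lower numbers stand for stronger inhibition and higher numbers for weaker inhibition:
- compound 1 `O=C1N=C(O)S/C1=C\c1ccc(OCCc2ccsc2)cc1` gives 60 nM
- compound 2 `O=C1NC(=O)/C(=C/c2ccc(OCCC3CCCCO3)cc2)S1` gives 750 nM

Compound 2 stands highest of the two numbers. Compound 1 is its nearest neighbour with a lower number, and the gap between them lies beyond the scatter. Compound 3 `COc1ccc(COc2ccc(/C=C3\SC(=O)NC3=O)cc2)cc1` carries 4-methoxyphenyl in place of (oxan-2-yl)methyl on a saturated chain carbon bound to an oxygen on an aromatic ring. Among the measured compounds shown here, no step between two measured compounds matches this change, so the outlook rests on the two numbers above alone; the aromatic side ring of compound 1 goes with the lower number. The expected step of a 3.8-fold lower number from compound 2 to compound 3 (0.57 log units; beyond the scatter) is therefore downward, beyond the scatter, though with a wide range. Compound 3 is estimated at 200 nM, between 60 nM and 700 nM.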

Compound 3, half-maximal inhibitory concentration: 529 nM
Compound 3: middle estimate off by 2.6-fold (0.42 log units), on the low side, and the stated range covers the measured number.
By their numbers in this assay, from the lowest: compound 1; then compounds 3 and 2 (each within the scatter of the next).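

In this assay, 4-methoxyphenyl in place of (oxan-2-yl)methyl on a saturated chain carbon bound to an oxygen on an aromatic ring gives a 1.4-fold lower number from compound 2 to compound 3 (0.15 log units; within the scatter), so this position does not separate the aromatic ring of carbon only from the non-aromatic ring with a hetero atom. This pair gives no support to reading the earlier gap between compound 1 and compound 2 as the mark of an aromatic side ring. No measurement at hand bears on the reason for this result.

Still open, on these data alone, is how the side ring of compound 1 reads on the core of compound 3. Also open, as far as these compounds go, is whether a basic amine such as a piperidine, or a carboxylic acid, at this position would move the number beyond the scatter.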